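Working notes on a pyridine amide series, step to compound 4

The source may report more compounds than this note shows. Statements on the series, on what has been measured and on what is new or still open speak of the compounds shown alone.

The compounds are compared in an in vitro functional assay on 1321-N1 cells for antagonist activity at transient receptor potential cation channel subfamily V member 1 (Homo sapiens), read by FLIPR and calcium flux; a higher number here means a more potent compound, by a factor of ten per unit of this negative logarithm, a lower number a less potent compound. Compound 1 `N#Cc1ccc(-c2ccc(C(=O)Nc3ccc4cccnc4c3)cn2)cc1` gives in this assay only a limit, < 6.6, which is the limit (the limit of < 6.6 in this assay, at which 1 of the 3 values shown sits). Compound 2 `Cc1nc(-c2ccc(F)cc2)ccc1C(=O)Nc1ccc2scnc2c1` gives 7.5 in this assay. Compound 3 `Cc1nc(-c2ccc(F)cc2)ccc1C(=O)Nc1ccc2sc(N(C)C)nc2c1` gives in this assay only a limit, < 5.8, which is the limit (the limit of < 5.8 in this assay, at which 1 of the 3 values shown sits). Among the compounds with values here, the single measured step is a number at least 1.70 log units lower from compound 2 to compound 3 (beyond the scatter). Compound 1 thus stands at a limit of this assay with no number of its own, and its standing against compound 2 and compound 3 is fixed only as far as that limit allows.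

Compound 4 `O=C(Nc1ccc2cccnc2c1)c1ccc(Cl)nc1` differs from compound 1 by chloro in place of 4-cyanophenyl on an aromatic carbon. Within the data shown here, the measured step concerns another group at another place on the shared core, so it does not bear on this change; no measured step covers the loss of the 4-cyanophenyl. The starting point is itself a limit, so a further fall in this assay would again be reported as a limit rather than a number. Compound 4 is expected to give 5.8 in this assay, within 5 to 6.6. The step that the limit leaves unreadable from compound 1 to compound 4 is expected to end below the reporting limit in most repeats.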

Compound 4, negative logarithm of the antagonist equilibrium constant: < 6.7
Compound 4: only a limit was reported; the forecaster's own chance of this, stated with the estimate: 80%; the middle value is on the limit's open side.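

Compound 4 gives in this assay only a limit, < 6.7. Compound 1 also stands at a limit, so no step can be read between compound 1 and compound 4. The compounds shown leave open whether chloro in place of 4-cyanophenyl changes the read-out at all, and if so, in which direction and by how much.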